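Removing one methoxy from compound 3

The source may hold more compounds than are shown below. What is called first, only, known or untested is meant among the compounds shown, and "the series" means these compounds.

Going by the values given here, in a functional assay on L1210 cells (Mus musculus) for antiproliferative activity, read by cell counting, with a stated time of 2 days (a higher number here means a weaker inhibitor, a lower number a stronger inhibitor), compound 3 (`COc1cc(C(=O)c2sc(N3CCCC3)nc2N)cc(OC)c1OC`) has the lowest number of the three compounds measured so far, at 370 nM, and its steps to both others lie beyond the scatter. Compound 1 (`CCN(CC)c1nc(N)c(C(=O)c2cc(OC)c(OC)c(OC)c2)s1`) gives 62000 nM, and compound 2 (`CCCCN(C)c1nc(N)c(C(=O)c2cc(OC)c(OC)c(OC)c2)s1`) gives 53000 nM.

Compound 4 (`COc1ccc(C(=O)c2sc(N3CCCC3)nc2N)cc1OC`) departs from compound 3 by a single change (hydrogen in place of methoxy on an aromatic carbon): hydrogen in place of methoxy on an aromatic carbon, ortho to a methoxy group and meta to a large group.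

Among the compounds with values here, no measured step tests this change, since all three measured compounds carry the same three methoxy groups. The measured steps all concern the amino group. They show that one replacement can move the number a long way, as in the large 170-fold lower number from compound 1 to compound 3 (2.22 log units; beyond the scatter) and the large 140-fold lower number from compound 2 to compound 3 (2.16 log units; beyond the scatter). Another replacement need not move it at all, as in a 1.2-fold lower number from compound 1 to compound 2 (0.07 log units; within the scatter), which lies within the scatter. The size of the new step therefore stays uncertain, but a clear move towards a weaker inhibitor seems likely. The step expected is a 16-fold higher number from compound 3 to compound 4 (1.21 log units; beyond the scatter) and the range is kept wide. Compound 4 is estimated at 6000 nM with an expected range from 1000 nM to 40000 nM.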

Compound 4, half-maximal inhibitory concentration: 60000 nM
The estimate for compound 4 lay 10-fold (1.00 log units) below the measured number; measured number above the stated range.
By their numbers in this assay, from the lowest: compound 3; then compounds 2, 4 and 1 (each within the scatter of the next).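

In this assay the methoxy that is ortho to a methoxy group and meta to a large group proves to count for a great deal, with the step of a 160-fold higher number from compound 3 to compound 4 (2.21 log units; beyond the scatter) being large. The earlier compounds shown here showed large steps only at the amino group, such as a 170-fold lower number from compound 1 to compound 3 (2.22 log units; beyond the scatter) and a 140-fold lower number from compound 2 to compound 3 (2.16 log units; beyond the scatter), whereas this step shows that a change on the other side of the shared core can be just as decisive. The pyrrolidin-1-yl group alone therefore does not secure the low number of compound 3, since compound 4 keeps that group and still gives 60000 nM in this assay, and no measurement on hand explains why this methoxy matters so much.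

The compounds shown leave open whether an ethoxy group, a hydroxy group or a fluorine atom in this place would retain the number of compound 3 or would behave like hydrogen. They also leave open whether the remaining methoxy groups count as heavily, and whether losing this methoxy would matter as much with diethylamino in place of pyrrolidin-1-yl.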